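A few compounds are considered here, and "the series" means these few. Any claim that something is new, unique, unknown or untested is made for them only; others in the source may bear on it.

Measured so far in an ADME assay on microsomes from liver (Mus musculus) for metabolic stability, read by LC-MS, with a stated time of 10 min; a higher number here means that more of the compound is left, a lower number that less of the compound is left:
Compound 1 `CN(C[C@H]1Cc2c(cccc2N2CCN(C3COC3)CC2)CN1)[C@H]1CCCc2cccnc21` with 50.8%
Compound 2 `CN(C[C@H]1Cc2c(cccc2N2CCN(C3CC3)CC2)CN1)[C@H]1CCCc2cccnc21` with 7%
Compound 3 `CC(C)N1CCN(c2cccc3c2C[C@H](CN(C)[C@H]2CCCc4cccnc42)NC3)CC1` with 15.1%

Compound 3 stands with compound 2 in the low part of this short series, the gap being a number 8.1 percentage points higher from compound 2 to compound 3 (within the scatter) in size, while the other gap is a number 35.7 percentage points lower from compound 1 to compound 3 (beyond the scatter) in size. Compound 4 `CN(C[C@H]1Cc2c(cccc2N2CCN(Cc3ccccn3)CC2)CN1)[C@H]1CCCc2cccnc21` has (pyridin-2-yl)methyl in place of isopropyl on an amine nitrogen in a ring and awaits measurement. At this nitrogen only oxetan-3-yl has stood apart, as a number 43.8 percentage points lower from compound 1 to compound 2 (beyond the scatter) also shows. No aromatic group has been tested there, so the two low compounds offer the closest guide. The expected change is a number 3.1 percentage points lower from compound 3 to compound 4 (within the scatter) and thus no clear shift. Compound 4 is estimated at 12% with an expected range from 3% to 30% in this measurement.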

Compound 4, percent of the compound remaining: 40.4%
Beside the measured number, compound 4's estimate is 28.4 percentage points below it; measured number above the stated range.
By their numbers in this assay, from the lowest: compounds 2 and 3 (each within the scatter of the next); then compound 4; then compound 1.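

In this assay, going by these compounds alone, oxetan-3-yl is no longer the only group at this amine nitrogen that stands apart from the low compounds: the change to (pyridin-2-yl)methyl gives a number 25.3 percentage points higher from compound 3 to compound 4 (beyond the scatter) and a number 33.4 percentage points higher from compound 2 to compound 4 (beyond the scatter). The new group still does not reach oxetan-3-yl, with a number 10.4 percentage points lower from compound 1 to compound 4 (beyond the scatter). No measured evidence accounts for these shifts.

The compounds shown leave open whether the ring nitrogen of the pyridine matters, which a benzyl group would test. They also leave open how pyridin-3-ylmethyl or pyridin-4-ylmethyl would compare.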